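Norbornane-bridged amide acids: N-alkyl chain variation, cytotoxicity

A few compounds are considered here, and "the series" means these few. Any claim that something is new, unique, unknown or untested is made for them only; others in the source may bear on it.

Measured compounds:
compound 1 `CCCCNC(=O)C1C(C(=O)O)[C@@H]2CC[C@H]1O2`, 10000 nM
compound 2 `O=C(O)CCCNC(=O)C1C(C(=O)O)[C@@H]2CC[C@H]1O2`, 10000 nM
compound 3 `O=C(O)CCCCCCCNC(=O)C1C(C(=O)O)[C@@H]2CC[C@H]1O2`, 10000 nM

In an ADME assay on NCI-H460 cells (Homo sapiens) for cytotoxicity, read by MTT assay, with a stated time of 72 h (on this read-out lower numbers stand for stronger inhibition of growth and higher numbers for weaker inhibition of growth), compound 1 gives 10000 nM, compound 2 gives 10000 nM and compound 3 gives 10000 nM. The change from compound 2 to compound 1 is methyl in place of carboxy on a saturated chain carbon, three bonds along the chain from an amide-type nitrogen; its step is no change at the digits printed from compound 2 to compound 1 (within the scatter). Lengthening the chain gives no change at the digits printed from compound 1 to compound 3 (within the scatter) and no change at the digits printed from compound 2 to compound 3 (within the scatter), so the three measured compounds sit together in this assay.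

Compound 4 `CCCCCCCCNC(=O)C1C(C(=O)O)[C@@H]2CC[C@H]1O2` is not yet measured. Its core differs from that of compound 2 by 4-carboxybutyl in place of carboxy on a saturated chain carbon, three bonds along the chain from an amide-type nitrogen. Relative to compound 3 the change is methyl in place of carboxy on a saturated chain carbon, seven bonds along the chain from an amide-type nitrogen. The same kind of change was made from compound 2 to compound 1, but there the place was three bonds along the chain from the amide-type nitrogen, whereas here it is seven bonds along the chain; it is therefore the same kind of change, not the same change.

Beside no change at the digits printed from compound 2 to compound 1 (within the scatter), the step from compound 3 to compound 4 is expected to be no change at the digits printed from compound 3 to compound 4 (within the scatter), resting on the flat run across compounds 1, 2 and 3, with compound 3 at 10000 nM. Compound 4 is estimated at 10000 nM, between 5000 nM and 20000 nM.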

Compound 4, concentration for 50% growth inhibition: 10000 nM
Compound 4: middle estimate and measured number agree at the digits printed, and the stated range covers the measured number.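

In this assay the change of carboxy to methyl gives no change at the digits printed from compound 3 to compound 4 (within the scatter), and it reads the same at both places on the chain: the same change on two cores in this assay, no change at the digits printed (within the scatter) from compound 2 to compound 1 and no change at the digits printed (within the scatter) from compound 3 to compound 4, 1.0-fold (0.00 log units) apart, within the scatter of two such steps

The other two steps to compound 4 agree with this, giving no change at the digits printed from compound 2 to compound 4 (within the scatter) and no change at the digits printed from compound 1 to compound 4 (within the scatter), so all four compounds stand level. This shows that, among these compounds, the change carries from one core to the other with no step to tell them apart, but a transfer of a null result shows only that no step appeared, not that the change would stay silent on a core where a step can be seen.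

The compounds shown leave open whether an amine or a phenyl group in place of the carboxy or methyl, or a chain longer than that of compound 4, would move the value in this assay. Also open, from the compounds shown here alone, is what happens when the shared core itself is altered, for instance when its carboxylic acid is replaced by an ester.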